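Notes on aryl exchange in a cytotoxic series

The source may report more compounds than this note shows. Statements on the series, on what has been measured and on what is new or still open speak of the compounds shown alone.

- compound 1 `COC1=C(C)C(=O)/C(=C(O)/C=C/c2ccc(Br)cc2)C(=O)C1(C)C` gives 1.9 ug/mL as its value
- compound 2 `COC1=C(C)C(=O)/C(=C(O)/C=C/c2ccc(F)cc2)C(=O)C1(C)C` gives 2.7 ug/mL as its value
- compound 3 `CCc1ccc(/C=C/C(O)=C2/C(=O)C(C)=C(OC)C(C)(C)C2=O)cc1` gives 1.9 ug/mL as its value

In a functional assay on KB cells (Homo sapiens) for cytotoxicity (on this read-out lower numbers stand for an effect already at smaller amounts and higher numbers for an effect only at larger amounts of compound), compound 3 gives 1.9 ug/mL as its number, the same digits as compound 1, and compound 2 stays within the scatter of both. The step to compound 4 `COC1=C(C)C(=O)/C(=C(O)/C=C/c2c(C)cccc2C)C(=O)C1(C)C` is 2,6-dimethylphenyl in place of 4-ethylphenyl on a double-bonded chain carbon bound to a double-bonded chain carbon with 2,6-dimethylphenyl in place of 4-ethylphenyl on a double-bonded chain carbon bound to a double-bonded chain carbon.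

Among the compounds with values here, three measured steps bear on it, each exchanging one group on an aromatic carbon: a 1.4-fold higher number from compound 1 to compound 2 (0.15 log units; within the scatter) and no change at the digits printed from compound 1 to compound 3 (within the scatter) and also a 1.4-fold lower number from compound 2 to compound 3 (0.15 log units; within the scatter) in this series. Within the data shown here, none of the measured compounds carries 2,6-dimethylphenyl, so these steps are only a loose guide. The expected step is a 1.3-fold higher number from compound 3 to compound 4 (0.12 log units; within the scatter) and no move beyond the scatter is expected. For compound 4 the estimated value is 2.5 ug/mL with an expected range from 1 ug/mL to 6 ug/mL given the missing direct precedent.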

Compound 4, concentration for half-maximal effect: 2.1 ug/mL
Compound 4: the middle estimate sits 1.2-fold (0.08 log units) above what was measured; the range from low to high includes it.
By their numbers in this assay, from the lowest: compounds 1, 3, 4 and 2 (each within the scatter of the next).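

At this position, on a double-bonded chain carbon bound to a double-bonded chain carbon, 2,6-dimethylphenyl in place of 4-ethylphenyl stays within the scatter in this assay (a 1.1-fold higher number from compound 3 to compound 4 (0.04 log units; within the scatter)), and the same holds against the other two aryl groups (a 1.3-fold lower number from compound 2 to compound 4 (0.11 log units; within the scatter); a 1.1-fold higher number from compound 1 to compound 4 (0.04 log units; within the scatter)). The earlier compounds shown here varied only the group on one aromatic carbon, whereas this change alters the substitution pattern of the ring at an equal count of heavy atoms, and all four compounds still lie within the scatter of the next in order. No measurement at hand offers a reason for this flat response.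

From the compounds shown here alone, whether any group at this position can move the number beyond the scatter stays open. A phenyl ring carrying an amine or a carboxylic acid, or a longer alkyl chain in place of the aryl group, would test that.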